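The source may report more compounds than this note shows. Statements on the series, on what has been measured and on what is new or still open speak of the compounds shown alone.

The shared core of compound 1 `CCOC(=O)c1c(N2CCCC2)[nH]c2ccc(O)cc12` carries a pyrrolidin-1-yl group, and for compound 1 the result in an assay on isolated protein for inhibition of Polyunsaturated fatty acid 5-lipoxygenase (Homo sapiens), tested at 10 uM (a lower number here means less inhibition, a higher number more inhibition at the concentration tested (going by the name of the read-out)), is "not determined" (no result reported), so it cannot be placed on the numbers at all. The two measured relatives carry larger groups at that same position. In this assay compound 2 `CCOC(=O)c1c(N2CCN(c3ccc(Cl)cc3)CC2)[nH]c2ccc(O)cc12` gives 69%, and compound 3 `CCOC(=O)c1c(N2CCN(c3ccc(Cc4ccccc4)cc3)CC2)[nH]c2ccc(O)cc12` gives 61%. Among the compounds with values here, the only measured step, a number 8 percentage points lower from compound 2 to compound 3 (within the scatter), shows that swapping one distant substituent for another left the read-out essentially unchanged. Compound 4 `CCOC(=O)c1c(Nc2cccnc2)[nH]c2ccc(O)cc12` arises from compound 1 through ((pyridin-3-yl)amino in place of pyrrolidin-1-yl on an aromatic carbon). Within the data shown here, no measured step touches this position, so the change cannot be weighed against any known pair; the measured step between compound 2 and compound 3 concerns a different part of the molecule and bears on it only in showing that the series as a whole sits in the middle range of inhibition. The estimate for compound 4 is therefore anchored loosely on compounds 2 and 3 and is 50%, between 20% and 80%.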

Compound 4, a percentage reported as inhibition, at one concentration (the size of the read-out at that concentration, not a potency): 24%
Compound 4: middle estimate off by 26 percentage points, on the high side; low and high end bracket the measured number.
By their numbers in this assay, from the lowest: compound 4; then compounds 3 and 2 (each within the scatter of the next).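

In this assay, within the data shown here, compound 1 gives "not determined" (no result reported) and so no step from it to compound 4 can be read. The compounds shown leave open how (pyridin-3-yl)amino in place of pyrrolidin-1-yl alone changes inhibition. No available evidence bears on the result for compound 4.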